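Swapping oxolan-3-yl for methyl on compound 1

The source may report more compounds than this note shows. Statements on the series, on what has been measured and on what is new or still open speak of the compounds shown alone.

In a functional assay on PC-3 cells (Homo sapiens) for cytotoxicity, read by MTT assay, with a stated time of 72 h (a lower number here means a stronger inhibitor, a higher number a weaker inhibitor), compound 1 (`COc1ccc(/C=N/NC(=O)Nc2cc3c(Nc4ccc(F)c(Cl)c4)ncnc3cc2O[C@H]2CCOC2)c(OC)c1OC`) gives 25600 nM as its read-out, level with compound 2 (`COc1cc(/C=N/NC(=O)Nc2cc3c(Nc4ccc(F)c(Cl)c4)ncnc3cc2O[C@H]2CCOC2)cc(OC)c1OC`) at 29600 nM and higher than compound 3 (`O=C(N/N=C/c1ccc(O)cc1O)Nc1cc2c(Nc3ccc(F)c(Cl)c3)ncnc2cc1O[C@H]1CCOC1`), which gives 7540 nM here. Compound 4 (`COc1cc2ncnc(Nc3ccc(F)c(Cl)c3)c2cc1NC(=O)N/N=C/c1ccc(OC)c(OC)c1OC`) carries methyl in place of oxolan-3-yl on an oxygen on an aromatic ring. The measured steps all lie elsewhere, on a carbon with a double bond to nitrogen: a 1.2-fold higher number from compound 1 to compound 2 (0.06 log units; within the scatter) stays within the scatter, and a 3.4-fold lower number from compound 1 to compound 3 (0.53 log units; beyond the scatter) and a 3.9-fold lower number from compound 2 to compound 3 (0.59 log units; beyond the scatter) are modest. None of them touches this oxygen, so they give no direction, and no step beyond the scatter is expected in this assay for this change. The estimated change is a 1.1-fold lower number from compound 1 to compound 4 (0.03 log units; within the scatter) in all. For compound 4 the expected value is 24000 nM within a range from 9000 nM to 60000 nM overall.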

Compound 4, half-maximal inhibitory concentration: 29300 nM
Estimate against measurement, compound 4: 1.2-fold (0.09 log units) below; the range from low to high includes it.
By their numbers in this assay, from the lowest: compound 3; then compounds 1, 4 and 2 (each within the scatter of the next).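

Going from (oxolan-3-yl)oxy to methoxy on an oxygen on an aromatic ring gives a 1.1-fold higher number from compound 1 to compound 4 (0.06 log units; within the scatter) in this assay and provides the first reading at this position. With the 2,3,4-trimethoxyphenyl group held constant, the read-out therefore does not depend on keeping oxolan-3-yl, its ring or its defined stereocentre. Nothing available explains why the number stays level.

On these data alone, whether methyl behaves the same way alongside the 2,4-dihydroxyphenyl group of compound 3 remains open. So does the effect of a longer chain ending in an amine or a carboxylic acid on this oxygen.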